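Swapping the furan arm of a hydroxamic acid

This account rests on a few compounds, and the source may have more. Where it says the series, first, only, none or still open, it means among the compounds named here.

Measured so far:
- compound 1, `O=C(NO)c1ccc(NCc2nc(-c3ccc(Br)o3)nn2-c2ccccc2)cc1`: 55.8%
- compound 2, `COc1ccc(-n2nc(-c3ccc(O)cc3)nc2CNc2ccc(C(=O)NO)cc2)cc1`: 70.3%
- compound 3, `NNC(=O)c1ccc(NCc2nc(-c3ccccc3)nn2-c2ccccc2)cc1`: 10%

Of the compounds shown here, three share one core and have been tested in an assay on Sf9 cells for inhibition of protein deacetylase HDAC6 (Homo sapiens), read by fluorescence, with a stated time of 40 min, tested at 100 nM; a lower number here means less inhibition, a higher number more inhibition at the concentration tested (going by the name of the read-out). Compound 1 stands second highest of the three. Compound 2 gives 70.3%, a number beyond the scatter above that of compound 1, and compound 3 gives 10%, far below it and also beyond the scatter.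

Compound 4, `CC(C)c1ccc(-c2nc(CNc3ccc(C(=O)NO)cc3)n(-c3ccccc3)n2)cc1`, is not yet measured. It differs from compound 1 in one place: 4-isopropylphenyl in place of 5-bromofuran-2-yl on an aromatic carbon. The aromatic group that sits on the core carbon between two ring nitrogen atoms is exchanged, while the hydroxamic acid and the phenyl on the ring nitrogen stay as in compound 1.

For the measured compounds named here, no pair of measured compounds shows this kind of exchange, so the size of the step can only be guessed. Compound 2, which also carries a six-membered carbon ring at that carbon, gives 70.3%, so a small rise or no change beyond the scatter seems most likely. Compound 4 is expected to give 62% in this assay, within 42% to 80%, an expected step of a number 6.2 percentage points higher from compound 1 to compound 4 (within the scatter).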

Compound 4, a percentage reported as inhibition, at one concentration (the size of the read-out at that concentration, not a potency): 27.6%
For compound 4 the middle estimate is 34.4 percentage points above the measured one; the measured number lies below the stated range.
By their numbers in this assay, from the lowest: compound 3; then compound 4; then compound 1; then compound 2.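

In this assay, the aromatic group on the carbon between two ring nitrogen atoms proves able to change the result on its own: the exchange of 5-bromofuran-2-yl for 4-isopropylphenyl gives a number 28.2 percentage points lower from compound 1 to compound 4 (beyond the scatter) while everything else in the molecule stays the same. For the compounds shown here, compound 1 and compound 4 are the first pair here to differ in one place, so this is the first size that can be read for any change at this position. No measurement shown gives a reason for this drop.

One exchange swaps the ring and adds the isopropyl group together, so the two cannot be told apart. Going by these compounds, a 4-methylphenyl group or a furan-2-yl group without the bromine at this carbon would help separate them, and how either would read remains open.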